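The source may hold more compounds than are shown below. What is called first, only, known or untested is meant among the compounds shown, and "the series" means these compounds.

Measured so far:

Compound 1 `CC(C)OC(=O)c1ccc(NC(=O)CCc2ccccc2)cc1-c1cccc(Cl)c1`: in a functional assay on HEK293 cells for antagonist activity at Voltage-dependent T-type calcium channel subunit alpha-1H (Homo sapiens), read by patch clamp, tested at 1 uM (on this read-out lower numbers stand for less inhibition and higher numbers for more inhibition at the one concentration tested (going by the name of the read-out)), compound 1 gives 6%.
Compound 2 `CC(C)OC(=O)CN(c1cccc(Cl)c1)S(=O)(=O)c1cccc(NC(=O)CN(C)C(=O)OCc2ccccc2)c1`: in this assay compound 2 gives 78%.
Compound 3 `CN(CC(=O)Nc1cccc(S(=O)(=O)N(CC(=O)O)c2cccc(Cl)c2)c1)C(=O)OCc1ccccc1`: in this assay compound 3 gives 11%.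

Compound 3 stands second highest of the three numbers; its nearest neighbour is compound 1, whose number is within the scatter of compound 3, and compound 2 lies far above it, beyond the scatter. Within the data shown here, the only step measured between two compounds differing in one place is a number 67 percentage points lower from compound 2 to compound 3 (beyond the scatter), a large loss when the isopropyl ester is opened to the free acid.

Compound 4 `CCOC(=O)CN(c1cccc(Cl)c1)S(=O)(=O)c1cccc(NC(=O)CN(C)C(=O)OCc2ccccc2)c1` carries the change (ethyl in place of hydrogen on an oxygen next to a carbonyl group). This runs the measured step in the opposite sense: the acid of compound 3 is capped again as an ester, here with a smaller group than in compound 2. Among the measured compounds shown here, since a number 67 percentage points lower from compound 2 to compound 3 (beyond the scatter) is the sole bearing step, a rise toward the level of compound 2 is expected, though with an ethyl rather than an isopropyl ester the full recovery is uncertain. For compound 4 the expected step is a number 49 percentage points higher from compound 3 to compound 4 (beyond the scatter), giving an estimate of 60% with a range from 30% to 85%.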

Compound 4, a percentage reported as inhibition, at one concentration (the size of the read-out at that concentration, not a potency): 35%
Compound 4: the middle estimate sits 25 percentage points above what was measured; low and high end bracket the measured number.
By their numbers in this assay, from the lowest: compounds 1 and 3 (each within the scatter of the next); then compound 4; then compound 2.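

In this assay, the ethyl ester recovers only part of what the free acid loses, with a number 24 percentage points higher from compound 3 to compound 4 (beyond the scatter). A single methyl on the ester group also counts at this oxygen, with a number 43 percentage points lower from compound 2 to compound 4 (beyond the scatter). The reading therefore depends on which alkyl group caps the carboxy group and not only on whether it is capped, rising from hydrogen through ethyl to isopropyl across compound 3, compound 4 and compound 2, although no available data explain this graded rise.

On these data alone, it remains open whether a methyl ester would fall between compound 3 and compound 4, and whether a tert-butyl group or a longer chain would extend the rise beyond compound 2. The response of a primary amide in place of the ester at this position is also unresolved.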